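Adding Chloro to the Pyridin-2-yl Group: Expected Solubility

This account rests on a few compounds, and the source may have more. Where it says the series, first, only, none or still open, it means among the compounds named here.

Of the compounds shown here, two have so far been measured in a physicochemical assay for solubility, read by HPLC, measured as thermodynamic solubility, with a stated time of 4 h, at pH 6.8; a lower number here means a less soluble compound, a higher number a more soluble compound. Compound 2 `Cn1c(COc2cccc(C(=O)O)c2)nc2ccc(Oc3ccccn3)cc21` gives 62 ug/mL in this assay, the higher of the two numbers. Compound 1 `Cn1c(COc2cccc(C(=O)O)c2)nc2ccc(Oc3ccc(Cl)c(F)c3)nc21`, which carries a different core and a different aryl ether, gives 1.7 ug/mL in this assay, and the two values show a wide gap between them. For the measured compounds named here, no pair of measured compounds differs in only one place, so there is no measured single step to lean on.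

Compound 3 `Cn1c(COc2cccc(C(=O)O)c2)nc2ccc(Oc3ccc(Cl)cn3)cc21` has not yet been measured. It differs from compound 2 in one place: chloro in place of hydrogen on an aromatic carbon. In words, chloro in place of hydrogen on an aromatic carbon, which turns the pyridin-2-yl group into a 5-chloropyridin-2-yl group.

Going by the values given here, with no measured step of this kind among the compounds, the size and direction can only be estimated from the change itself, and a decrease beyond the scatter is expected, the step being a 3.4-fold lower number from compound 2 to compound 3 (0.54 log units; beyond the scatter). Compound 3 is therefore expected to give about 18 ug/mL in this assay, with a range from 6 ug/mL to 50 ug/mL.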

Compound 3, solubility: 17 ug/mL
Compound 3: the middle estimate sits 1.1-fold (0.02 log units) above what was measured; measured number inside the range.
By their numbers in this assay, from the lowest: compound 1; then compound 3; then compound 2.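

In this assay the series now has its first measured change in one place: chloro in place of hydrogen on an aromatic carbon, two atoms from the ring nitrogen and para to a large group, goes with a 3.6-fold lower number from compound 2 to compound 3 (0.56 log units; beyond the scatter). This shows that the position on the pyridin-2-yl group is not a silent one, since a single added heavy atom, 1 chlorine, is enough to carry the number beyond the usual scatter, though the step counts as modest. Nothing measured here explains why the number moves with this change.

On these data alone, this is one step on one scaffold, so it remains unknown whether turning pyridin-2-yl into 5-chloropyridin-2-yl would give a step of similar size and direction on the core of compound 1, or whether chloro would do the same on another carbon of the ring. Nor do the compounds shown say how a methoxy group, an amine or a nitrile on this same carbon would compare with chloro or with hydrogen.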